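Working notes: methyl on the sulfur ring and cytotoxicity

This account rests on a few compounds, and the source may have more. Where it says the series, first, only, none or still open, it means among the compounds named here.

Measured so far in an ADME assay on THP-1 cells (Homo sapiens) for cytotoxicity; on this read-out lower numbers stand for higher toxicity in this test and higher numbers for lower toxicity in this test:
compound 1 `O[C@@H]1Cc2ccccc2N[C@H](c2cccs2)C1` gives 773000 nM
compound 2 `Cc1ccsc1[C@@H]1C[C@H](O)Cc2ccccc2N1` gives 579000 nM
compound 3 `O[C@@H]1Cc2cc(OC(F)(F)F)ccc2N[C@H](c2cccs2)C1` gives 61500 nM

Compound 2 differs from compound 1 by methyl in place of hydrogen on an aromatic carbon, and the step is a 1.3-fold lower number from compound 1 to compound 2 (0.13 log units; within the scatter). Compound 3 differs from compound 1 by trifluoromethoxy in place of hydrogen on an aromatic carbon, a step of a 13-fold lower number from compound 1 to compound 3 (1.10 log units; beyond the scatter), leaving compound 3 with the lowest number of the three. Compound 4 `Cc1ccc([C@@H]2C[C@H](O)Cc3cc(OC(F)(F)F)ccc3N2)s1` is not yet measured; it differs from compound 3 by methyl in place of hydrogen on an aromatic carbon. This is the same kind of change as from compound 1 to compound 2, not the same: there the methyl sits next to the ring atom that bears a large group, two ring bonds from the ring sulfur; here it sits next to the ring sulfur, two ring bonds from the ring atom that bears a large group. The cores of compound 3 and compound 1 differ as stated above for compound 3 against compound 1.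

The expected step is a 1.2-fold lower number from compound 3 to compound 4 (0.09 log units; within the scatter), because the same kind of change once gave only a 1.3-fold lower number from compound 1 to compound 2 (0.13 log units; within the scatter); a single earlier case at a different place is a thin basis. For compound 4 the estimate in this assay is 50000 nM, with 25000 nM to 100000 nM as the expected range.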

Compound 4, half-maximal cytotoxic concentration: 98000 nM
Estimate against measurement, compound 4: 2.0-fold (0.29 log units) below; the measured number falls inside the stated range.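

In this assay the methyl step on the core carrying trifluoromethoxy reads a 1.6-fold higher number from compound 3 to compound 4 (0.20 log units; within the scatter) and stands with the earlier methyl step as one result: the same change on two cores in this assay, a 1.3-fold lower number (0.13 log units; within the scatter) from compound 1 to compound 2 and a 1.6-fold higher number (0.20 log units; within the scatter) from compound 3 to compound 4, 2.1-fold (0.33 log units) apart, within the scatter of two such steps

Within these two pairs, methyl on the sulfur ring carries from the core of compound 1 to the core of compound 3 with no readable change in the number, whereas the trifluoromethoxy step itself is large at a 13-fold lower number from compound 1 to compound 3 (1.10 log units; beyond the scatter) in the same test. This does not separate core from place: in compound 4 the methyl sits next to the ring sulfur, in compound 2 it sits elsewhere on that ring, and each place is seen on one core only, so two pairs set no rule for other cores.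

Open, going by these compounds, is how the two methyl places compare on a single core. Also open, on these data alone, is whether a group other than methyl on the sulfur ring, such as a chlorine, an amine or a carboxylic acid, would carry between these cores in the same way.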